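Tetrahydropyranylmethyl and dioxolanylmethyl esters against monoglyceride lipase

The source may hold more compounds than are shown below. What is called first, only, known or untested is meant among the compounds shown, and "the series" means these compounds.

For the measured compounds named here, three esters have numbers so far. Compound 1 `CCCCC/C=C\C/C=C\C/C=C\C/C=C\CCCC(=O)OC[C@@H]1COC(C)(C)O1` gives 38% in an assay on membranes from cerebellum for inhibition of Monoglyceride lipase (Rattus norvegicus), tested at 100 uM; a higher number here means more inhibition at the concentration tested (going by the name of the read-out), a lower number less inhibition. Compound 2 `O=C(OCC1CCCCO1)c1ccccc1` gives 24% in this assay. Compound 3 `CC/C=C\C/C=C\C/C=C\CCCCCCCC(=O)OCC1CCCCO1` gives 33% in this assay; its number sits within the usual scatter of both compound 1 and compound 2, so the three cannot be ordered.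

Compound 4 `CCCCCC/C=C\CCCCCCCC(=O)OCC1CCCCO1` is not yet measured. It differs from compound 3 in one place: pentyl in place of hepta-1,4-dien-1-yl on a saturated chain carbon bound to a double-bonded chain carbon. Going by the values given here, no step between measured compounds speaks to this kind of change. With the three numbers so close together, no step beyond the scatter is expected, and the step from compound 3 to compound 4 is estimated as a number 3 percentage points lower from compound 3 to compound 4 (within the scatter). Compound 4 is expected to give about 30% in this assay, within 15% to 45%.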

Compound 4, a percentage reported as inhibition, at one concentration (the size of the read-out at that concentration, not a potency): 36%
Beside the measured number, compound 4's estimate is 6 percentage points below it; low and high end bracket the measured number.
By their numbers in this assay, from the lowest: compounds 2, 3, 4 and 1 (each within the scatter of the next, the first and the last beyond it).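

In this assay, pentyl in place of hepta-1,4-dien-1-yl on a saturated chain carbon bound to a double-bonded chain carbon gives a number 3 percentage points higher from compound 3 to compound 4 (within the scatter), the first step read at this position. The read-out therefore does not separate these two groups, so the double bonds of hepta-1,4-dien-1-yl are not required to retain this level of inhibition. No measured evidence explains this result.

As far as these compounds go, a saturated chain of the same length, or a terminal carboxylic acid or amine on the chain, remains open. The compounds shown also leave open whether any change at this position moves the read-out beyond the scatter.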